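Thiophene for chlorophenyl on the compound 3 core

A few compounds are considered here, and "the series" means these few. Any claim that something is new, unique, unknown or untested is made for them only; others in the source may bear on it.

Measured so far:
compound 1, `CCCCCCCCc1ccc(OCC(=O)Cn2nnc(-c3cccc(Cl)c3)n2)cc1`: 24 nM
compound 2, `CCCCCCCCc1ccc(OCC(=O)Cn2nnc(CCC(=O)O)n2)cc1`: 30 nM
compound 3, `CCCCCCCCc1ccc(OCC(=O)Cn2nnnc2-c2cccc(Cl)c2)cc1`: 360 nM

All three numbers come from an assay on microsomes from brain for inhibition of Fatty-acid amide hydrolase 1 (Rattus norvegicus), read by fluorescence and HPLC, with a stated time of 60 min; on this read-out higher numbers stand for weaker inhibition and lower numbers for stronger inhibition. Compound 3 stands at the top of the three numbers shown; compound 2 is the nearest of the other two and compound 1 the furthest, and both of those gaps lie beyond the scatter. Compound 3 and compound 1 carry the same two groups on differently arranged cores, so the gap between them is not a single-point step and is not counted here.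

Compound 4, `CCCCCCCCc1ccc(OCC(=O)Cn2nnnc2-c2cccs2)cc1`, differs from compound 3 in one place: thiophen-2-yl in place of 3-chlorophenyl on an aromatic carbon. For the measured compounds named here, the only single-point step measured, a 1.3-fold higher number from compound 1 to compound 2 (0.10 log units; within the scatter), sits on the other core arrangement and exchanges an aromatic group for a chain, so it does not bear on the swap at hand. Going by the values given here, no measured pair shows one aromatic group replaced by another on the core that compound 3 and compound 4 share. With nothing to anchor a direction, the step from compound 3 to compound 4 is expected to stay within the scatter in this assay, so no change at the digits printed from compound 3 to compound 4 (within the scatter) is the estimated change. Compound 4 is accordingly expected to give about 360 nM, with a range from 120 nM to 1100 nM.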

Compound 4, half-maximal inhibitory concentration: 55 nM
Estimate against measurement, compound 4: 6.5-fold (0.82 log units) above; the whole stated range lies above it.
By their numbers in this assay, from the lowest: compounds 1, 2 and 4 (each within the scatter of the next, the first and the last beyond it); then compound 3.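

On the core shared by compound 3 and compound 4, the group on the aromatic carbon of the five-membered aromatic ring with 4 nitrogen matters: in this assay, thiophen-2-yl in place of 3-chlorophenyl gives a 6.5-fold lower number from compound 3 to compound 4 (0.82 log units; beyond the scatter) at this place. For the compounds shown here, this is the first measured exchange of one aromatic group for another on this core and the first single-point step beyond the scatter, whereas a 1.3-fold higher number from compound 1 to compound 2 (0.10 log units; within the scatter) on the other core arrangement stayed within it. Nothing measured here accounts for the lower number, so the step stands as an observation only.

As far as these compounds go, it remains open whether the step follows the change to a five-membered ring with a sulfur atom or the loss of the chlorine, a question that unsubstituted phenyl or furan-2-yl at this place would help to separate. Also open, from the compounds shown here alone, is whether thiophen-2-yl on the core of compound 1, or a carboxylic acid chain such as 2-carboxyethyl on the core of compound 3, would behave in the same way.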